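Side-chain unsaturation and tolerated concentration on HEL cells

A few compounds are considered here, and "the series" means these few. Any claim that something is new, unique, unknown or untested is made for them only; others in the source may bear on it.

Three compounds of one shared core have been examined in a functional assay on HEL cells (Homo sapiens) for cytotoxicity, read by microscopy; a lower number here means that less compound is tolerated, a higher number that more compound is tolerated. Compound 1 `CCCCCCc1cc2cn([C@H]3C[C@H](O)[C@@H](CO)O3)c(=O)nc2o1` gives in this assay a value of > 50000 nM, which is a limit of the assay rather than a number. Compound 2 `CCCCCCCCc1cc2cn([C@H]3C[C@H](O)[C@@H](CO)O3)c(=O)nc2o1` gives in this assay a value of > 50000 nM, again only a limit. Compound 3 `C=CCCCc1cc2cn([C@H]3C[C@H](O)[C@@H](CO)O3)c(=O)nc2o1` gives in this assay a value of > 200000 nM, which is likewise a limit.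

Because every value sits at the limit of > 200000 nM in this assay, at which 1 of the 3 values shown sits, or at the limit of > 50000 nM in this assay, at which 2 of the 3 values shown sit, none of the steps between them can be read: the step that the two limits leave unreadable from compound 1 to compound 2 stays unreadable, as do a step that the two limits leave unreadable from compound 1 to compound 3 and a step that the two limits leave unreadable from compound 2 to compound 3. Compound 3 therefore stands only at a limit, with no number to place it against the other two.

Compound 4 `C#CCCCc1cc2cn([C@H]3C[C@H](O)[C@@H](CO)O3)c(=O)nc2o1` differs from compound 3 by ethynyl in place of vinyl on a saturated chain carbon, three bonds along the chain from an aromatic carbon. The measured steps that change this chain, from compound 1 and compound 2 to compound 3, bear on it, yet each is unreadable, so no step beyond the scatter can be expected in this assay. The estimated step of a number no higher from compound 3 to compound 4 (the limit leaves the size open) is accordingly flat. Compound 4 is expected to give 200000 nM, in a range from 50000 nM to 400000 nM, most likely again reported only as a limit.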

Compound 4, minimum cytotoxic concentration: > 200000 nM
Compound 4 ended at the assay's limit; the forecaster's own chance of this, stated with the estimate: 85%; the middle value lies on the limit itself.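

In this assay compound 4 gives > 200000 nM, which is a limit and not a number. Within the data shown here, no step from compound 1, compound 2 or compound 3 to compound 4 can be read. The compounds shown leave open whether any of these side chains differs from the others in the concentration tolerated, and by how much.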